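The source may report more compounds than this note shows. Statements on the series, on what has been measured and on what is new or still open speak of the compounds shown alone.

Compound 1, with the structure `COc1cccc(NC2=CC(=O)c3nc4n(c3C2=O)[C@H]2OC[C@@H](O)[C@H]2OC4)c1`, gives 4280 nM in a functional assay on HeLa cells (Homo sapiens) for inhibition, read by sulforhodamine B assay (a higher number here means a weaker inhibitor, a lower number a stronger inhibitor), the lowest of the three numbers in hand. Compound 2, `Cc1ccc(NC2=CC(=O)c3c(nc4n3[C@H]3OC[C@@H](O)[C@H]3OC4)C2=O)cc1`, gives 6590 nM in this assay, a number that lies within the scatter of the number for compound 1. Compound 3, `O=C1C(Nc2ccccc2F)=CC(=O)c2c1nc1n2[C@H]2OC[C@@H](O)[C@H]2OC1`, gives 9820 nM in this assay, a higher number than compound 1 by a margin that goes beyond the scatter. Going by the values given here, the one measured step between close relatives is a 1.5-fold higher number from compound 2 to compound 3 (0.17 log units; within the scatter), so swapping one aryl group for another on the amine nitrogen has so far moved this assay by little.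

Compound 4, `O=C1C=C(Nc2ccc(Br)cc2)C(=O)c2c1nc1n2[C@H]2OC[C@@H](O)[C@H]2OC1`, is the next member of the series. The change from compound 1 is 4-bromophenyl in place of 3-methoxyphenyl on an amine nitrogen. The step from compound 2 to compound 3 is the only one that bears directly on this kind of exchange, and it stayed within the scatter; the spread from compound 1 to compound 3 shows that such exchanges can reach a little further. A small rise in the number is therefore expected, no larger than the spread already seen, giving a 1.4-fold higher number from compound 1 to compound 4 (0.15 log units; within the scatter). Compound 4 is expected to give about 6000 nM in this assay, within a range of 3000 nM to 12000 nM.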

Compound 4, half-maximal inhibitory concentration: 3830 nM
Compound 4: the middle estimate sits 1.6-fold (0.19 log units) above what was measured; low and high end bracket the measured number.
By their numbers in this assay, from the lowest: compounds 4, 1, 2 and 3 (each within the scatter of the next, the first and the last beyond it).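

In this assay, going by these compounds alone, the exchange of 3-methoxyphenyl for 4-bromophenyl on the amine nitrogen gives a 1.1-fold lower number from compound 1 to compound 4 (0.05 log units; within the scatter) and thus shows that this position accepts a ring bearing bromine as readily as one bearing methoxy, a kind of substituent not seen among the earlier compounds. The group that leaves counts one hydrogen-bond acceptor and the group that enters counts none, yet for this pair that difference in count comes with no change that can be read beyond the scatter, so the acceptor of the 3-methoxyphenyl group is not required to hold the number at this level. No measurement at hand speaks to why the two compounds sit so close together.

All four compounds shown carry a substituted phenyl ring on this nitrogen, so they leave open how the number would respond to a pyridine ring, a benzyl group or an open alkyl chain in its place. They also leave open whether a carboxylic acid or an amine on the phenyl ring would move the number beyond the narrow band seen so far.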